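Methoxy to isopropyl on the 4-substituted phenyl ring

The compounds below may be only part of what the source reports. "The series", "measured", "known", "first", "only" and "open" are said of these compounds alone.

Of the compounds shown here, three of the shared core have been measured in a functional assay, read by spectrophotometry, tested at 100 uM; a higher number here means a weaker inhibitor, a lower number a stronger inhibitor. Compound 1 `O=C(/C=C/c1ccccc1)c1cccc(NC(=O)c2cc(-c3ccncc3)n[nH]2)c1` gives 71500 nM. Compound 2 `COc1ccc(/C=C/C(=O)c2cccc(NC(=O)c3cc(-c4ccncc4)n[nH]3)c2)cc1` gives 54600 nM and compound 3 `COc1ccccc1/C=C/C(=O)c1cccc(NC(=O)c2cc(-c3ccncc3)n[nH]2)c1` gives 56700 nM. The number for compound 2 is the lowest of the three, but both of its steps to the others are within the scatter: a 1.3-fold lower number from compound 1 to compound 2 (0.12 log units; within the scatter) and a 1.0-fold higher number from compound 2 to compound 3 (0.02 log units; within the scatter). The remaining step, a 1.3-fold lower number from compound 1 to compound 3 (0.10 log units; within the scatter), is also within the scatter, so neither adding a methoxy group nor exchanging the 4-methoxyphenyl for the 2-methoxyphenyl arrangement moved this assay beyond the noise.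

Compound 4 `CC(C)c1ccc(/C=C/C(=O)c2cccc(NC(=O)c3cc(-c4ccncc4)n[nH]3)c2)cc1` is not yet measured. Against compound 2 the change is isopropyl in place of methoxy on an aromatic carbon, that is 4-methoxyphenyl becomes 4-isopropylphenyl. Going by the values given here, no measured step involves an isopropyl group; the only steps that bear on this position are the three above, all small, showing this part of the molecule accepting methoxy changes without a shift in this assay. The expected step is therefore a 1.0-fold higher number from compound 2 to compound 4 (0.00 log units; within the scatter), nothing beyond the scatter. Compound 4 is estimated at 55000 nM, within 25000 nM to 120000 nM.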

Compound 4, half-maximal inhibitory concentration: 60200 nM
For compound 4 the middle estimate is 1.1-fold (0.04 log units) below the measured one, within the range that was stated.
By their numbers in this assay, from the lowest: compounds 2, 3, 4 and 1 (each within the scatter of the next).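

Isopropyl in place of methoxy on the aromatic carbon removes the hydrogen-bond acceptor of the leaving group, yet in this assay the step stays within the scatter (a 1.1-fold higher number from compound 2 to compound 4 (0.04 log units; within the scatter)), so among these compounds an oxygen at this place is not needed to keep the number in this range. The comparisons with the 2-methoxyphenyl compound (a 1.1-fold higher number from compound 3 to compound 4 (0.03 log units; within the scatter)) and the unsubstituted phenyl compound (a 1.2-fold lower number from compound 1 to compound 4 (0.07 log units; within the scatter)) are also within the scatter, which extends the flat picture at this position to a carbon-only group of three heavy atoms. No supporting evidence bears on this result.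

Only hydrogen, methoxy and isopropyl are shown on this ring, and none of them separates from the others. As far as these compounds go, whether an amine, a carboxylic acid or a longer alkyl chain here would give a step beyond the scatter remains open.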